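Replacing the 1H-indol-3-yl of compound 1 with 4-(tert-butyl)phenyl

A few compounds are considered here, and "the series" means these few. Any claim that something is new, unique, unknown or untested is made for them only; others in the source may bear on it.

Compound 1 `COc1cc(-c2ccnc3cc(-c4c[nH]c5ccccc45)nn23)cc(OC)c1OC` holds the lowest of the three numbers in a functional assay on B16-F0 cells (Mus musculus) for inhibition, read by CCK-8 assay, with a stated time of 48 h (on this read-out lower numbers stand for stronger inhibition and higher numbers for weaker inhibition), giving 40 nM. Compound 2 `COc1cc(-c2ccnc3cc(-c4ccc(C)c(C)c4)nn23)cc(OC)c1OC` gives 391 nM and compound 3 `COc1ccc(-c2cc3nccc(-c4cc(OC)c(OC)c(OC)c4)n3n2)cc1F` gives 3950 nM, so a 9.8-fold higher number from compound 1 to compound 2 (0.99 log units; beyond the scatter) is modest and a 99-fold higher number from compound 1 to compound 3 (1.99 log units; beyond the scatter) is large, while a 10-fold higher number from compound 2 to compound 3 (1.00 log units; beyond the scatter) separates the two phenyl variants. Compound 4 `COc1cc(-c2ccnc3cc(-c4ccc(C(C)(C)C)cc4)nn23)cc(OC)c1OC` differs from compound 1 by 4-(tert-butyl)phenyl in place of 1H-indol-3-yl on an aromatic carbon; the group that leaves carries one hydrogen-bond donor, the group that enters none. Both measured steps away from 1H-indol-3-yl lead to a six-membered carbon-only ring and both give higher numbers, compound 2 being the closer analogy. Compound 4 is therefore expected to show a 10-fold higher number from compound 1 to compound 4 (1.00 log units; beyond the scatter), estimated at 400 nM in this assay, between 120 nM and 1500 nM.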

Compound 4, half-maximal inhibitory concentration: > 10000 nM
Compound 4: no number, only a limit (the forecaster's own chance of this, stated with the estimate: 3%); at least 25-fold (1.39 log units) between middle value and limit.
By their numbers in this assay, from the lowest: compound 1; then compound 2; then compound 3. At a limit, above all of these: compound 4.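

In this assay compound 4 gives only a limit, not a number: the limit of > 10000 nM in this assay, at which 1 of the 4 values shown sits. Replacing 1H-indol-3-yl with 4-(tert-butyl)phenyl gives an at least 250-fold higher number from compound 1 to compound 4 (2.39 log units; beyond the scatter), and the other two aryl groups also compare favourably, with an at least 25-fold higher number from compound 2 to compound 4 (1.40 log units; beyond the scatter) and an at least 2.5-fold higher number from compound 3 to compound 4 (0.40 log units; beyond the scatter). So the group on this aromatic carbon can take the read-out beyond the range spanned by the earlier compounds, and 4-(tert-butyl)phenyl is the least tolerated of the four groups shown.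

The compounds shown leave open whether the loss follows the tert-butyl group or the absence of the indole's hydrogen-bond donor. A 1-methyl-1H-indol-3-yl or an unsubstituted phenyl at this place would help separate the two.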